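The compounds below may be only part of what the source reports. "The series", "measured", "known", "first", "only" and "open" are said of these compounds alone.

Compound 1, with the structure `Nc1ncnc2c1ccn2-c1ccc(NC(=O)c2ccc(Cl)c(C(F)(F)F)c2)cc1`, is the reference point of this small set. In a functional assay on A375P cells (Homo sapiens) for antiproliferative activity, read by MTT assay, with a stated time of 24 h (on this read-out lower numbers stand for stronger inhibition and higher numbers for weaker inhibition), compound 1 gives 2900 nM, and this is the only actual number shown. The one other result, that of compound 2, is a limit of the assay rather than a number. Compound 2, with the structure `CC(=O)Nc1ncnc2c1ccn2-c1ccc(NC(=O)c2ccc(Cl)c(C(F)(F)F)c2)cc1`, reaches only the limit > 10000 nM in this assay. The step of an at least 3.4-fold higher number from compound 1 to compound 2 (0.53 log units; beyond the scatter) therefore describes a weakening that is at least modest, with one of the two values sitting at the limit of > 10000 nM in this assay, at which 1 of the 2 values shown sits.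

Compound 3, with the structure `Nc1ncnc2c1ccn2-c1ccc(NC(=O)c2cccc(C(F)(F)F)c2)cc1`, has not yet been measured. Compared with compound 1 the change is hydrogen in place of chloro on an aromatic carbon. The only measured step, from compound 1 to compound 2, concerns the nitrogen on the aromatic ring and not the chloro group, so no shown step speaks directly to this change. With nothing to suggest a large shift, compound 3 is expected to give 5000 nM in this assay, with a range from 2000 nM to 15000 nM. That corresponds to an expected step of a 1.7-fold higher number from compound 1 to compound 3 (0.24 log units; within the scatter), which is estimated to be small.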

Compound 3, half-maximal inhibitory concentration: 9700 nM
Compound 3: the middle estimate sits 1.9-fold (0.29 log units) below what was measured; the range from low to high includes it.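

The chloro group, which sits ortho to a trifluoromethyl group, matters in this assay: replacing it with hydrogen gives a 3.3-fold higher number from compound 1 to compound 3 (0.52 log units; beyond the scatter). This single heavy atom on the aromatic ring that carries the trifluoromethyl group is therefore a second place where one change weakens the read-out, alongside the nitrogen that bears the acetyl group in compound 2. The top of the measurable range is a limit, reached by compound 2, and not a number, which matters when judging how much room remains for further weakening in this series: the limit of > 10000 nM in this assay, at which 1 of the 3 values shown sits.

The compounds shown do not tell whether the chlorine atom itself is needed or whether a fluoro, bromo, methyl or methoxy group in the same place would keep or improve the activity of compound 1. They also leave open what happens when the trifluoromethyl group is exchanged for another group, such as a nitrile, with the chloro group kept in place.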